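Cytotoxicity notes on esters of compound 1

The compounds below may be only part of what the source reports. "The series", "measured", "known", "first", "only" and "open" are said of these compounds alone.

Measured so far in a toxicity assay on A549 cells (Homo sapiens) for cytotoxicity, read by luminescence and CellTiter-Glo, with a stated time of 24 h; on this read-out lower numbers stand for higher toxicity in this test and higher numbers for lower toxicity in this test:
compound 1 `COc1cccc2[nH]c(C(=O)N[C@@H](CC(C)C)C(=O)N[C@@H](C[C@@H]3CCCNC3=O)C(=O)CO)cc12`: > 200000 nM, a limit of this assay
compound 2 `COc1cccc2[nH]c(C(=O)N[C@@H](CC(C)C)C(=O)N[C@@H](C[C@@H]3CCCNC3=O)C(=O)COC(=O)C3(C(F)(F)F)CCCCC3)cc12`: > 200000 nM, a limit of this assay

Compound 1 stands only at a limit in this assay; no number is known for it. Compound 2 likewise gives only a limit. The step that the two limits leave unreadable from compound 1 to compound 2 therefore cannot be read in size or direction because both values sit at the limit of > 200000 nM in this assay, at which 2 of the 2 values shown sit. For the measured compounds named here, whether attaching the group of 12 heavy atoms on the oxygen of the saturated carbon changed cytotoxicity at all is thus unknown; the single measured step shows only that cytotoxicity stayed out of range.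

Compound 3 `COc1cccc2[nH]c(C(=O)N[C@@H](CC(C)C)C(=O)N[C@@H](C[C@@H]3CCCNC3=O)C(=O)COC(=O)c3c(C)nc(C)nc3C)cc12` differs from compound 1 by (2,4,6-trimethylpyrimidin-5-yl)carbonyl in place of hydrogen on an oxygen on a saturated carbon, again an acyl group on the same oxygen. Going by the values given here, the one step that bears on it, from compound 1 to compound 2, is unreadable, so no direction can be taken from it; the only evidence is that both comparators sit at the limit. Compound 3 is therefore expected to stay near the limit as well, with a step of a number no higher from compound 1 to compound 3 (the limit leaves the size open) expected to be none beyond the scatter, and an estimate for compound 3 in this assay of 200000 nM within 100000 nM to 400000 nM.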

Compound 3, half-maximal cytotoxic concentration: > 200000 nM
Compound 3: no number, only a limit (the forecaster's own chance of this, stated with the estimate: 85%); the middle value sits exactly at the limit.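

For the compounds shown here, no step among compound 1, compound 2 and compound 3 can be read, in size or in direction, because all three share one bound: the limit of > 200000 nM in this assay, at which 3 of the 3 values shown sit.

The compounds shown leave open whether an acyl group on this oxygen changes the result in this assay at all, and what number compound 1 itself would give.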